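Thiophene replacement on the shared core of compound 1

The compounds below may be only part of what the source reports. "The series", "measured", "known", "first", "only" and "open" are said of these compounds alone.

Compound 1 `Cc1cc(-c2nc3sc(C)cn3c2/C=N/NC(=N)N)c(C)s1` gives 47900 nM in a functional assay on cells (Leukemia cell, Homo sapiens) for inhibition (a lower number here means a stronger inhibitor of growth, a higher number a weaker inhibitor of growth), the highest of the three numbers in hand: compound 2 `Cc1cn2c(/C=N/Nc3ccccn3)c(-c3ccc(Cl)c([N+](=O)[O-])c3)nc2s1` gives 16600 nM and compound 3 `Cc1cc(-c2nc3sccn3c2/C=N/NC(=N)N)c(C)s1` gives 15500 nM. Compound 4 `Cc1cn2c(/C=N/NC(=N)N)c(-c3cccs3)nc2s1` differs from compound 1 by thiophen-2-yl in place of 2,5-dimethylthiophen-3-yl on an aromatic carbon. For the measured compounds named here, no measured step alters the same group. Going by the values given here, the only single step known, a 3.1-fold lower number from compound 1 to compound 3 (0.49 log units; beyond the scatter), removes a methyl elsewhere on the core and gives a modest gain. Compound 4 also loses methyl groups, though on the pendant ring, so a step of similar or smaller size, or none beyond the scatter, is expected. Compound 4 is therefore estimated at 25000 nM, within 8000 nM to 80000 nM, which would mean a 1.9-fold lower number from compound 1 to compound 4 (0.28 log units; within the scatter).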

Compound 4, concentration for 50% growth inhibition: 1820 nM
For compound 4 the middle estimate is 14-fold (1.14 log units) above the measured one, outside the stated range (below it).
By their numbers in this assay, from the lowest: compound 4; then compounds 3 and 2 (each within the scatter of the next); then compound 1.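

In this assay, for the compounds shown here, the pendant ring at this position proves far more sensitive than the earlier compounds suggested: thiophen-2-yl in place of 2,5-dimethylthiophen-3-yl gives a 26-fold lower number from compound 1 to compound 4 (1.42 log units; beyond the scatter), a large step, whereas the step of a 3.1-fold lower number from compound 1 to compound 3 (0.49 log units; beyond the scatter) on the core is modest. The available data offer no explanation for the size of this step.

Still open, on these data alone, is whether the gain follows the lost methyl groups or the changed ring attachment, which a thiophen-3-yl group would help separate. Also open, as far as these compounds go, is whether thiophen-2-yl and the core hydrogen of compound 3 combine.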